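This account rests on a few compounds, and the source may have more. Where it says the series, first, only, none or still open, it means among the compounds named here.

Compound 1 `CN1C/C(=C\c2ccc(F)cc2)C(=O)/C(=C/c2cccc([N+](=O)[O-])c2)C1`: 17600 nM
Compound 2 `CN1C/C(=C\c2ccc(Br)cc2)C(=O)/C(=C/c2cccc([N+](=O)[O-])c2)C1`: 9850 nM
Compound 3 `CN1C/C(=C\c2cccc([N+](=O)[O-])c2)C(=O)/C(=C/c2ccc(Cl)cc2Cl)C1`: 14000 nM

In an ADME assay on L02 cells (Homo sapiens) for cytotoxicity, read by MTT assay, with a stated time of 24 h (on this read-out higher numbers stand for weaker inhibition and lower numbers for stronger inhibition), compound 3 gives 14000 nM and stands among the other two, but all three values lie within the scatter of one another, so none can be ranked above another. The change to compound 4 `CN1C/C(=C\c2cccc(Br)c2)C(=O)/C(=C/c2cccc([N+](=O)[O-])c2)C1` is 3-bromophenyl in place of 2,4-dichlorophenyl on a double-bonded chain carbon bound to a double-bonded ring carbon on a double-bonded chain carbon bound to a double-bonded ring carbon. Two measured swaps bear on it: a 1.8-fold lower number from compound 1 to compound 2 (0.25 log units; within the scatter) for bromo in place of fluoro and a 1.4-fold higher number from compound 2 to compound 3 (0.15 log units; within the scatter) for 2,4-dichlorophenyl in place of 4-bromophenyl. Going by the values given here, both stayed within the scatter, although no measured compound carries 3-bromophenyl. The expected step is a 1.2-fold lower number from compound 3 to compound 4 (0.07 log units; within the scatter) and so none beyond the scatter. For compound 4 the estimated value is 12000 nM with an expected range from 6500 nM to 22000 nM.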

Compound 4, half-maximal inhibitory concentration: 8070 nM
Compound 4: middle estimate off by 1.5-fold (0.17 log units), on the high side, within the range that was stated.
By their numbers in this assay, from the lowest: compounds 4, 2, 3 and 1 (each within the scatter of the next, the first and the last beyond it).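

In this assay, 3-bromophenyl in place of 4-bromophenyl gives a 1.2-fold lower number from compound 2 to compound 4 (0.09 log units; within the scatter), so at this place the two bromophenyl groups cannot be told apart. 3-Bromophenyl in place of 2,4-dichlorophenyl gives a 1.7-fold lower number from compound 3 to compound 4 (0.24 log units; within the scatter), again no real difference. Going by these compounds alone, only 3-bromophenyl in place of 4-fluorophenyl, at a 2.2-fold lower number from compound 1 to compound 4 (0.34 log units; beyond the scatter), is the first step in this set to pass the scatter, and it is modest. Nothing measured here gives a reason for these steps. Going by these compounds, whether an amine or a carboxylic acid on this phenyl ring would shift the number remains open.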